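Compound 3 to Compound 4: Exchange on the Carbonyl Carbon

The compounds below may be only part of what the source reports. "The series", "measured", "known", "first", "only" and "open" are said of these compounds alone.

Of the compounds shown here, three sharing one core have been tested in a functional assay on KB cells (Homo sapiens) for cytotoxicity, read by MTT assay, with a stated time of 72 h; on this read-out higher numbers stand for weaker inhibition and lower numbers for stronger inhibition. Compound 1 `COc1cc2ncnc(NNC(=S)NC(=O)c3ccc(C(F)(F)F)cc3)c2cc1OC` gives 8840 nM, compound 2 `COc1cc2ncnc(NNC(=S)NC(=O)c3ccccc3)c2cc1OC` gives 3770 nM, and compound 3 `COc1cc2ncnc(NNC(=S)NC(=O)c3cccc(Cl)c3)c2cc1OC` gives 4830 nM. For the measured compounds named here, the only step beyond the scatter is a 2.3-fold lower number from compound 1 to compound 2 (0.37 log units; beyond the scatter), a modest one; a 1.8-fold lower number from compound 1 to compound 3 (0.26 log units; within the scatter) and a 1.3-fold higher number from compound 2 to compound 3 (0.11 log units; within the scatter) both stay within it. Compound 3 therefore stands second highest of the three numbers, nearest to compound 2 and furthest from compound 1, with neither gap beyond the scatter.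

Compound 4 `COc1cc2ncnc(NNC(=S)NC(=O)c3ccc(C)cc3)c2cc1OC` differs from compound 3 by 4-methylphenyl in place of 3-chlorophenyl on a carbonyl carbon, that is, (3-chlorophenyl)carbonyl to (4-methylphenyl)carbonyl. Going by the values given here, the steps that bear on it are the exchanges on the same ring: the modest lowering in a 2.3-fold lower number from compound 1 to compound 2 (0.37 log units; beyond the scatter) and the flat result in a 1.3-fold higher number from compound 2 to compound 3 (0.11 log units; within the scatter). Such changes have moved this assay little, so no step beyond the scatter is expected, and compound 4 is estimated at 4000 nM (range 1800 nM to 9000 nM), a step of a 1.2-fold lower number from compound 3 to compound 4 (0.08 log units; within the scatter) that is expected to remain within the scatter.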

Compound 4, half-maximal inhibitory concentration: 24200 nM
Beside the measured number, compound 4's estimate is 6.1-fold (0.78 log units) below it; the whole stated range lies below it.
By their numbers in this assay, from the lowest: compounds 2, 3 and 1 (each within the scatter of the next, the first and the last beyond it); then compound 4.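

In this assay, the aryl group on the carbonyl carbon proves less tolerant of change than the first three compounds suggested: 4-methylphenyl in place of 3-chlorophenyl gives a 5.0-fold higher number from compound 3 to compound 4 (0.70 log units; beyond the scatter). The same group stands out in the other two comparisons, with methyl in place of hydrogen giving a 6.4-fold higher number from compound 2 to compound 4 (0.81 log units; beyond the scatter) and methyl in place of trifluoromethyl giving a 2.7-fold higher number from compound 1 to compound 4 (0.44 log units; beyond the scatter), so a small group on this aromatic carbon can shift the number beyond the scatter, and methyl does so more than trifluoromethyl. Nothing available explains why methyl has this effect.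

Going by these compounds, it remains open whether 3-methylphenyl would follow 4-methylphenyl or stay with 3-chlorophenyl. Also open, on these data alone, is how an amine or a carboxylic acid on this ring would compare with methyl.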